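Swapping Phenyl for Dichlorophenyl Where Every Value Is a Limit

A few compounds are considered here, and "the series" means these few. Any claim that something is new, unique, unknown or untested is made for them only; others in the source may bear on it.

Of the compounds shown here, three have been tested so far in a functional assay on NCI-H460 cells (Homo sapiens) for cytotoxicity, read by MTT assay; a higher number here means a weaker inhibitor, a lower number a stronger inhibitor. Compound 1 `COc1ccc(/C=C/C(=O)c2sc(Nc3ccc(Cl)c(Cl)c3)nc2C)cc1` gives only a limit, > 25000 nM. Compound 2 `Cc1nc(Nc2ccccc2)sc1C(=O)/C=C/c1ccccc1` also reaches only a limit, > 25000 nM. Compound 3 `Cc1nc(Nc2ccccc2)sc1C(=O)/C=C/c1ccccc1Cl` likewise stops at a limit, > 25000 nM. Because every value shown sits at the limit of > 25000 nM in this assay, at which 3 of the 3 values shown sit, none of these compounds has a measured potency, and the one single-point comparison available, the change a step that the two limits leave unreadable from compound 2 to compound 3, cannot be read for size or direction.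

Compound 4 `Cc1nc(Nc2ccc(Cl)c(Cl)c2)sc1C(=O)/C=C/c1ccccc1` is compound 2 with 3,4-dichlorophenyl in place of phenyl on a nitrogen on an aromatic ring. Compound 1 carries the same 3,4-dichlorophenyl group, and its value is also only a limit. Going by the values given here, no measured step bears directly on the change from compound 2 to compound 4, and the one step at hand is unreadable. The expectation for compound 4 is therefore no change beyond the scatter, a step that the limit leaves unreadable from compound 2 to compound 4. Compound 4 is estimated at 40000 nM, within 12000 nM to 150000 nM, and is most likely to be reported again as a limit rather than a number.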

Compound 4, half-maximal inhibitory concentration: 22700 nM
Beside the measured number, compound 4's estimate is 1.8-fold (0.25 log units) above it; the range from low to high includes it.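

In this assay, going by these compounds alone, compound 4 gives 22700 nM, the first real number in this set rather than a limit. Placing 3,4-dichlorophenyl on the nitrogen in place of phenyl gives an at least 1.1-fold lower number from compound 2 to compound 4 (0.04 log units; that floor lies within the scatter), and hydrogen in place of methoxy on an aromatic carbon gives an at least 1.1-fold lower number from compound 1 to compound 4 (0.04 log units; that floor lies within the scatter). Both floors lie within the scatter, so neither change is shown to matter, and the full size of each step stays unknown because the compounds they start from carry only a limit: the limit of > 25000 nM in this assay, at which 3 of the 4 values shown sit.

As far as these compounds go, whether either chlorine alone would give a measurable number remains open. So does the effect of an amine or a carboxylic acid on the aromatic ring attached to the nitrogen.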